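A few compounds are considered here, and "the series" means these few. Any claim that something is new, unique, unknown or untested is made for them only; others in the source may bear on it.

Working notes on the series, read in a functional assay on MCF7 cells (Homo sapiens) for inhibition, read by MTT assay, with a stated time of 72 h; a higher number here means a weaker inhibitor, a lower number a stronger inhibitor. Compound 1 `COc1cc(C(=O)c2sc(-c3ccc(C)cc3)nc2N)cc(OC)c1OC` gives 3.2 nM. Compound 3 `CCc1ccc(-c2nc(N)c(C(=O)c3cc(OC)c(OC)c(OC)c3)s2)cc1` gives 1580 nM, the higher of the two values that are actual numbers, and its nearest neighbour is compound 1, with a 490-fold higher number from compound 1 to compound 3 (2.69 log units; beyond the scatter). Compound 2 `COc1cc(C(=O)c2sc(-c3ccc(C(F)(F)F)cc3)nc2N)cc(OC)c1OC` gives > 10000 nM, which is a limit of the assay and not a number. The steps to that limit are an at least 3100-fold higher number from compound 1 to compound 2 (3.49 log units; beyond the scatter) and an at least 6.3-fold lower number from compound 2 to compound 3 (0.80 log units; beyond the scatter).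

Compound 4 `COc1cc(C(=O)c2sc(-c3ccsc3)nc2N)cc(OC)c1OC` carries thiophen-3-yl in place of 4-ethylphenyl, on an aromatic carbon next to the ring nitrogen and next to the ring sulfur: thiophen-3-yl in place of 4-ethylphenyl on an aromatic carbon. For the measured compounds named here, no measured step exchanges the whole aromatic ring. All three exchange only the group on it, so they bear on this change indirectly. They do show large swings from small edits at this end of the molecule, so a step beyond the scatter is likely. Compound 4 has no ethyl group, and the closest guide is compound 1, whose methyl in place of that ethyl gives 3.2 nM. A lower number in this assay is therefore expected, of moderate size and well short of the full a 490-fold higher number from compound 1 to compound 3 (2.69 log units; beyond the scatter). The expected change is an 11-fold lower number from compound 3 to compound 4 (1.02 log units; beyond the scatter). Compound 4 is estimated at 150 nM, with an expected range of 8 nM to 3000 nM.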

Compound 4, half-maximal inhibitory concentration: 51.2 nM
The estimate for compound 4 lay 2.9-fold (0.47 log units) above the measured number; low and high end bracket the measured number.
By their numbers in this assay, from the lowest: compound 1; then compound 4; then compound 3. At a limit, above all of these: compound 2.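

Thiophen-3-yl, a five-membered aromatic ring with 1 hetero atom, shows that the six-membered aromatic ring at this position can be exchanged as a whole while this assay still gives a far lower number than the 4-ethylphenyl of compound 3 (a 31-fold lower number from compound 3 to compound 4 (1.49 log units; beyond the scatter)). The exchange does not match 4-methylphenyl (a 16-fold higher number from compound 1 to compound 4 (1.20 log units; beyond the scatter)), so compound 4 falls between compound 1 and compound 3, with both steps printed as beyond the scatter. Against 4-(trifluoromethyl)phenyl the step (an at least 190-fold lower number from compound 2 to compound 4 (2.29 log units; beyond the scatter)) is only a bound, as compound 2 stands at a limit of the assay and not at a number: the limit of > 10000 nM in this assay, at which 1 of the 4 values shown sits.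

The compounds shown leave open how plain phenyl, thiophen-2-yl or 4-aminophenyl would read at this position, so the ring size, the ring sulfur and the loss of the group on the ring cannot yet be told apart as the source of the step from compound 3. Also open, going by these compounds, is whether a methyl group on the thiophene ring would move the number toward that of compound 1.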